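Ethynyl on the lead of a halogen-sensitive series

The source may hold more compounds than are shown below. What is called first, only, known or untested is meant among the compounds shown, and "the series" means these compounds.

Values in a functional assay on MDA-MB-231 cells (Homo sapiens) for antiproliferative activity, read by MTT assay, with a stated time of 72 h; on this read-out lower numbers stand for stronger inhibition and higher numbers for weaker inhibition
compound 1 `O=C(CCc1cccc2c1B(O)OC2)Nc1ccccc1` gives 230 nM
compound 2 `O=C(CCc1cccc2c1B(O)OC2)Nc1ccc(Br)cc1` gives 5300 nM
compound 3 `O=C(CCc1cccc2c1B(O)OC2)Nc1ccc(I)cc1` gives 33000 nM

Compound 1 holds the lowest number of the three, and both measured substitutions on it move upward. Bromo in place of hydrogen gives a 23-fold higher number from compound 1 to compound 2 (1.36 log units; beyond the scatter) as a large step. Iodo in place of hydrogen gives a 140-fold higher number from compound 1 to compound 3 (2.16 log units; beyond the scatter) as a larger one, and the exchange of the two halogens gives a 6.2-fold higher number from compound 2 to compound 3 (0.79 log units; beyond the scatter) as a modest step.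

Compound 4 `C#Cc1cccc(NC(=O)CCc2cccc3c2B(O)OC3)c1` differs from compound 1 by ethynyl in place of hydrogen on an aromatic carbon in one place, with ethynyl in place of hydrogen on an aromatic carbon, meta to a large group. Among the measured compounds shown here, no measured step involves ethynyl itself, so the halogen steps are only a rough guide. With compound 2 at 5300 nM as the nearest reference, an upward move is expected, probably no larger than that bromo step. The estimated change is a 6.5-fold higher number from compound 1 to compound 4 (0.81 log units; beyond the scatter) in this series. Compound 4 is estimated at 1500 nM with an expected range from 250 nM to 9000 nM in this assay for now.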

Compound 4, half-maximal inhibitory concentration: 1600 nM
Beside the measured number, compound 4's estimate is 1.1-fold (0.03 log units) below it; the range from low to high includes it.
By their numbers in this assay, from the lowest: compound 1; then compound 4; then compound 2; then compound 3.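

In this assay, ethynyl in place of hydrogen on an aromatic carbon, meta to a large group, gives a 7.0-fold higher number from compound 1 to compound 4 (0.84 log units; beyond the scatter), so the upward move on this ring is not confined to the two halogens. With this step, every substituent shown on the ring leaves a higher number than compound 1, and the pattern now extends to a carbon-only group with no hydrogen-bond donors or acceptors, placed where neither halogen sits. Nothing measured here bears on why the number rises.

Open, as far as these compounds go, is whether the rise belongs to the ethynyl group or to its place on the ring, which bromo or ethynyl at each other's carbon would separate. Also open, from the compounds shown here alone, is whether an amine or a carboxylic acid on this same carbon would move the number in the same direction.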